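This account rests on a few compounds, and the source may have more. Where it says the series, first, only, none or still open, it means among the compounds named here.

Working notes on the series in a functional assay on Raji cells (Homo sapiens) for antiproliferative activity, read by CCK-8 assay, with a stated time of 72 h, tested at 40 uM; a lower number here means less inhibition, a higher number more inhibition at the concentration tested (going by the name of the read-out).

Three compounds carry the shared core and differ only in the aryl group on the amide carbonyl. Compound 1 `CCOC(=O)c1sc(-c2cccc(NC(=O)c3ccc(C(F)(F)F)cc3)c2)nc1Nc1ccc(N2CCN(C)CC2)cc1` gives 33%. Compound 2 `CCOC(=O)c1sc(-c2cccc(NC(=O)c3ccc(F)cc3)c2)nc1Nc1ccc(N2CCN(C)CC2)cc1` gives 16.8%, and the change of fluoro in place of trifluoromethyl on an aromatic carbon reads as a number 16.2 percentage points lower from compound 1 to compound 2 (beyond the scatter). Compound 3 `CCOC(=O)c1sc(-c2cccc(NC(=O)c3ccccc3F)c2)nc1Nc1ccc(N2CCN(C)CC2)cc1` gives 89.8%; the step with 2-fluorophenyl in place of 4-(trifluoromethyl)phenyl on a carbonyl carbon is a number 56.8 percentage points higher from compound 1 to compound 3 (beyond the scatter), and that with 2-fluorophenyl in place of 4-fluorophenyl on a carbonyl carbon is a number 73 percentage points higher from compound 2 to compound 3 (beyond the scatter). Compound 3 therefore stands highest of the three, beyond the scatter against both compound 1 and compound 2.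

Compound 4 `CN1CCN(c2ccc(Nc3nc(-c4cccc(NC(=O)c5ccccc5F)c4)sc3C(=O)O)cc2)CC1` keeps the amide of compound 3 and differs only at the ester: hydrogen in place of ethyl on an oxygen next to a carbonyl group. Among the measured compounds shown here, none of the measured steps touches this position; all three concern the aryl group on the carbonyl carbon, so they give no direct guide to the size or direction of the step. For the measured compounds named here, with the amide of compound 3 retained and no step of this kind measured, the expectation for compound 4 is a modest decrease, a number 29.8 percentage points lower from compound 3 to compound 4 (beyond the scatter), with a wide spread. Compound 4 is estimated at 60%, within 20% to 90%.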

Compound 4, a percentage reported as inhibition, at one concentration (the size of the read-out at that concentration, not a potency): 86.9%
Beside the measured number, compound 4's estimate is 26.9 percentage points below it; low and high end bracket the measured number.
By their numbers in this assay, from the lowest: compound 2; then compound 1; then compounds 4 and 3 (each within the scatter of the next).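

In this assay, among the compounds shown here, this pair gives the first reading at the ester position: hydrogen in place of ethyl on an oxygen next to a carbonyl group gives a number 2.9 percentage points lower from compound 3 to compound 4 (within the scatter), so with the 2-fluorophenyl amide, the ethoxycarbonyl and carboxy forms cannot be told apart. Each earlier step concerned the aryl group on the carbonyl carbon and lay beyond the scatter, whereas this change of ethoxy to hydroxy stays within it, so in this one pair the read-out holds with the ethyl gone. Nothing measured here accounts for compound 3 and compound 4 reading alike.

Going by these compounds, whether the same change would also stay within the scatter with the 4-fluorophenyl amide of compound 2 or the 4-(trifluoromethyl)phenyl amide of compound 1 remains open. Also open, on these data alone, is how a primary amide, a nitrile or a longer ester chain such as butyl would read at this position, and whether a read-out at a single concentration conceals any difference in potency between compound 3 and compound 4.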